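The source may hold more compounds than are shown below. What is called first, only, known or untested is meant among the compounds shown, and "the series" means these compounds.

Measured in an ADME assay on LLC-PK1 cells (Sus scrofa) for permeability; on this read-out lower numbers stand for lower permeability and higher numbers for higher permeability:
- Compound 1 `COC[C@]12C[C@H]1[C@@](C)(c1cc(NC(=O)c3ccc(Cl)cn3)cc(F)c1F)N=C(N)S2`: 13 10^-6 cm/s
- Compound 2 `CNC(=O)[C@]12C[C@H]1[C@@](C)(c1cc(NC(=O)c3ccc(Cl)cn3)cc(F)c1F)N=C(N)S2`: 29 10^-6 cm/s
- Compound 3 `CN(C)C(=O)[C@]12C[C@H]1[C@@](C)(c1cc(NC(=O)c3ccc(Cl)cn3)cc(F)c1F)N=C(N)S2`: 40 10^-6 cm/s

Compound 1 stands lowest of these three, and both of the other compounds lie beyond the scatter from it. Its methoxymethyl group gives way to an amide in the two modest steps, a 2.2-fold higher number from compound 1 to compound 2 (0.35 log units; beyond the scatter) and a 3.1-fold higher number from compound 1 to compound 3 (0.49 log units; beyond the scatter). Adding a methyl on the amide-type nitrogen gives a 1.4-fold higher number from compound 2 to compound 3 (0.14 log units; within the scatter), which stays within the scatter.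

The next compound to be tested is compound 4 `CCOc1cnc(C(=O)Nc2cc(F)c(F)c([C@@]3(C)N=C(N)S[C@@]4(COC)C[C@H]43)c2)cn1`, which has not yet been measured. Its change from compound 1 lies elsewhere: 5-ethoxypyrazin-2-yl in place of 5-chloropyridin-2-yl on a carbonyl carbon. In words, 5-ethoxypyrazin-2-yl stands in place of 5-chloropyridin-2-yl on a carbonyl carbon.

Among the compounds with values here, none of the measured steps touches that group, since all of them concern a saturated ring carbon or an amide-type nitrogen. Within the data shown here, they show only that single changes have so far been modest or smaller, and they give no direction for this one. No step beyond the scatter is therefore expected, and the estimate amounts to a 1.2-fold higher number from compound 1 to compound 4 (0.06 log units; within the scatter). For compound 4 the estimated value in this assay is 15 10^-6 cm/s, with an expected range from 7 10^-6 cm/s to 30 10^-6 cm/s.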

Compound 4, apparent permeability: 25 10^-6 cm/s
Estimate against measurement, compound 4: 1.7-fold (0.22 log units) below; the range from low to high includes it.
By their numbers in this assay, from the lowest: compounds 1, 4, 2 and 3 (each within the scatter of the next, the first and the last beyond it).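

Within the data shown here, this is the first reading at the group on the carbonyl carbon, as all the earlier steps concerned a saturated ring carbon or an amide-type nitrogen: in this assay, replacing 5-chloropyridin-2-yl with 5-ethoxypyrazin-2-yl gives a 1.9-fold higher number from compound 1 to compound 4 (0.28 log units; within the scatter). The entering group has more heavy atoms, one more ring hetero atom and more hydrogen-bond acceptors than the group it replaces, yet this exchange of one aromatic ring for another stays inside the usual scatter, so on this single pair the position accepts the larger group without a step that can be told from repeat noise. Nothing measured here gives a reason for the size of this step, and no explanation can be offered for it.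

The compounds shown leave open how this step divides between the ethoxy group and the second ring nitrogen, which a 5-ethoxypyridin-2-yl or a 5-chloropyrazin-2-yl group on the same carbonyl carbon would separate. They also leave open whether a longer chain such as propoxy in place of ethoxy stays as close to compound 1, and whether 5-ethoxypyrazin-2-yl gives a similar step alongside dimethylcarbamoyl on the saturated ring carbon.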